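Phenylethenyl in place of aminophenyl: working notes

A few compounds are considered here, and "the series" means these few. Any claim that something is new, unique, unknown or untested is made for them only; others in the source may bear on it.

Measured compounds:
compound 1, `COc1cc(C(=O)c2cn(-c3ccccc3)cc2-c2ccc(N)cc2)cc(OC)c1OC`, 9 nM
compound 2, `COc1cc(C(=O)c2cn(-c3cc(OC)c(OC)c(OC)c3)cc2-c2ccccc2)cc(OC)c1OC`, > 5000 nM
unmeasured: compound 3, `COc1cc(C(=O)c2cn(-c3ccccc3)cc2/C=C/c2ccccc2)cc(OC)c1OC`

Going by the values given here, in a functional assay on MCF7 cells (Homo sapiens) for cytotoxicity, read by MTT assay, with a stated time of 96 h (a higher number here means a weaker inhibitor, a lower number a stronger inhibitor), compound 1 gives 9 nM, which is the only numeric value in the set. For compound 2 the result of > 5000 nM in this assay is a limit of the assay, not a number. Thus (the limit of > 5000 nM in this assay, at which 1 of the 2 values shown sits); compound 1 therefore stands at the potent end of what has been measured, with no second number to rank it against. Among the compounds with values here, no step between two measured compounds is available that changes one place only, so the change from compound 1 to compound 3 is not backed by a measured precedent.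

Compound 3 differs from compound 1 by 2-phenylethenyl in place of 4-aminophenyl on an aromatic carbon. The aminophenyl of compound 1 carries one hydrogen-bond donor and one acceptor; the entering 2-phenylethenyl carries none, and adds one double bond outside aromatic rings. With compound 1 at 9 nM as the sole anchor, the expectation for a 22-fold higher number from compound 1 to compound 3 (1.35 log units; beyond the scatter) is a loss beyond the scatter, of moderate size. Compound 3 is estimated at 200 nM in this assay, within a range from 20 nM to 2000 nM.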

Compound 3, half-maximal inhibitory concentration: 2200 nM
The estimate for compound 3 lay 11-fold (1.04 log units) below the measured number; the measured number lies above the stated range.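

The change at this position gives a 240-fold higher number from compound 1 to compound 3 (2.39 log units; beyond the scatter) in this assay, and it is the only step shown that changes one place alone. The entering 2-phenylethenyl also carries a six-membered aromatic ring of carbon only, so such a ring at this aromatic carbon of the five-membered ring is not enough on its own to keep the number of compound 1 on the shared core. The change removes the hydrogen-bond donor and acceptor of the 4-aminophenyl and adds a double bond outside aromatic rings, and nothing shown gives a reason for the step or separates these differences.

The compounds shown leave open whether the loss follows the amine or the double bond, and a 2-phenylethyl group or a 4-hydroxyphenyl group at this place would bear on that question. Going by these compounds alone, compound 2 is a limit of the assay and not a number, and it differs from compound 1 in more than one place, so it adds no step at this position.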